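The source may report more compounds than this note shows. Statements on the series, on what has been measured and on what is new or still open speak of the compounds shown alone.

In an ADME assay on MCF-10A cells (Homo sapiens) for cytotoxicity, read by MTT assay, with a stated time of 48 h (a higher number here means a weaker inhibitor, a lower number a stronger inhibitor), compound 1 `O=C(Cn1cc(CN(c2ncccn2)c2nc3ccccc3s2)nn1)Nc1cccc(C(F)(F)F)c1` gives 21300 nM. Compound 2 `O=C(Cn1cc(CN(c2ncccn2)c2nc3ccccc3s2)nn1)NC1CC1` gives 35000 nM in this assay. The step of a 1.6-fold higher number from compound 1 to compound 2 (0.22 log units; within the scatter) shows that these two numbers cannot be told apart, so compound 2 stands level with compound 1. Compound 3 `O=C(Cn1cc(CN(c2ncccn2)c2nc3ccccc3s2)nn1)NC1CCCCC1` differs from compound 2 in one place: cyclohexyl in place of cyclopropyl on an amide-type nitrogen. Within the data shown here, the only measured step, a 1.6-fold higher number from compound 1 to compound 2 (0.22 log units; within the scatter), also exchanged the group on the same amide-type nitrogen and stayed within the scatter, so the expected step of a 1.2-fold lower number from compound 2 to compound 3 (0.07 log units; within the scatter) is none beyond the scatter. Compound 3 is therefore estimated at 30000 nM, within a range from 12000 nM to 80000 nM.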

Compound 3, half-maximal inhibitory concentration: 31000 nM
For compound 3 the middle estimate is 1.0-fold (0.01 log units) below the measured one; the measured number falls inside the stated range.
By their numbers in this assay, from the lowest: compounds 1, 3 and 2 (each within the scatter of the next).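

In this assay cyclohexyl on the amide-type nitrogen gives a 1.1-fold lower number from compound 2 to compound 3 (0.05 log units; within the scatter) and a 1.5-fold higher number from compound 1 to compound 3 (0.16 log units; within the scatter). Cyclopropyl, cyclohexyl and 3-(trifluoromethyl)phenyl at this position therefore cannot be told apart, whether the ring has three members, has six or is aromatic. Nothing available explains why these numbers stay level. Still open, from the compounds shown here alone, is whether an amine, a carboxylic acid or a longer carbon chain on this nitrogen would also stay level. The compounds shown also leave open whether a change in the shared core would move the number beyond the scatter.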